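This account rests on a few compounds, and the source may have more. Where it says the series, first, only, none or still open, it means among the compounds named here.

Compound 2 `Nc1ccccc1NC(=O)c1ccc(Cn2cnc3c(Nc4ccc(-c5ccccn5)cc4)nc(Cl)nc32)cc1` holds the lower of the two numbers shown in a functional assay on NCI-H460 cells (Homo sapiens) for antiproliferative activity, read by CCK-8 assay, with a stated time of 72 h, tested at 8 uM (a lower number here means a weaker effect, a higher number a stronger effect of the compound at the concentration tested), where compound 2 gives 30.8%. Among the compounds with values here, compound 1 `Nc1ccccc1NC(=O)c1ccc(Cn2cnc3c(NCc4ccccc4)nc(Cl)nc32)cc1` gives 61.2%, and the single measured step is a number 30.4 percentage points lower from compound 1 to compound 2 (beyond the scatter). Compound 3 `Nc1ccccc1NC(=O)c1ccc(Cn2cnc3c(Nc4cccc(Cl)c4)nc(Cl)nc32)cc1` differs from compound 2 by 3-chlorophenyl in place of 4-(pyridin-2-yl)phenyl on a nitrogen on an aromatic ring. Within the data shown here, no measured step covers this exchange; the one known step only shows that a 4-(pyridin-2-yl)phenyl group gave a lower number than benzyl, so the direction for 3-chlorophenyl is open. Compound 3 is therefore expected near compound 2, with a wide margin: 40% (range 18% to 62%), a step of a number 9.2 percentage points higher from compound 2 to compound 3 (within the scatter), which may well stay within the scatter.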

Compound 3, a percentage reported as inhibition, at one concentration (the size of the read-out at that concentration, not a potency): 67%
Estimate against measurement, compound 3: 27 percentage points below; measured number above the stated range.
By their numbers in this assay, from the lowest: compound 2; then compounds 1 and 3 (each within the scatter of the next).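

The 3-chlorophenyl group shows that an aromatic ring on this nitrogen does not by itself bring the low number: in this assay the exchange for 4-(pyridin-2-yl)phenyl gives a number 36.2 percentage points higher from compound 2 to compound 3 (beyond the scatter). Against benzyl, the same group gives a number 5.8 percentage points higher from compound 1 to compound 3 (within the scatter), so these two groups cannot be told apart here. No evidence at hand explains either step. Open remains whether the chlorine matters, and how an unsubstituted phenyl or a longer chain ending in an amine would read on this nitrogen.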